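The source may report more compounds than this note shows. Statements on the series, on what has been measured and on what is new or still open speak of the compounds shown alone.

Working notes on the selenocyanate carbamate series. Compound 2 `N#C[Se]c1ccc(NC(=O)OCc2ccccc2)cc1` is measured in a functional assay on MCF7 cells (Homo sapiens) for cytotoxicity, read by MTT assay, with a stated time of 72 h (on this read-out lower numbers stand for stronger inhibition of growth and higher numbers for weaker inhibition of growth), and gives 38800 nM. Compound 1 `N#C[Se]c1ccc(NC(=O)OCc2ccc([N+](=O)[O-])cc2)cc1` gives 40700 nM and compound 3 `CCCCOC(=O)Nc1ccc([Se][Se]c2ccc(NC(=O)OCCCC)cc2)cc1` gives 46300 nM; both numbers lie within the scatter of the number for compound 2, so the three measured compounds cannot be told apart on this read-out. Going by the values given here, the only single-point step recorded, hydrogen in place of nitro on an aromatic carbon, is a 1.0-fold lower number from compound 1 to compound 2 (0.02 log units; within the scatter), and it carries no information beyond the scatter.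

Compound 4 `CCCCCCOC(=O)Nc1ccc([Se]C#N)cc1` is not yet measured in this assay. It differs from compound 2 by pentyl in place of phenyl on a saturated chain carbon bound to an oxygen next to a carbonyl group. Among the compounds with values here, no measured step touches this part of the molecule, so no direct comparison exists; compound 3, which also carries a chain in place of the aryl group on the carbamate oxygen, gives a number within the scatter of the others. The step of a 1.1-fold higher number from compound 2 to compound 4 (0.03 log units; within the scatter) is therefore expected to be none beyond the scatter. For compound 4 the estimate in this assay is 42000 nM, with a range from 20000 nM to 88000 nM.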

Compound 4, concentration for total growth inhibition: 30500 nM
Compound 4: the middle estimate sits 1.4-fold (0.14 log units) above what was measured; the measured number falls inside the stated range.
By their numbers in this assay, from the lowest: compounds 4, 2, 1 and 3 (each within the scatter of the next).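

In this assay, the change of phenyl to pentyl on a saturated chain carbon bound to an oxygen next to a carbonyl group gives a 1.3-fold lower number from compound 2 to compound 4 (0.10 log units; within the scatter). Unlike the earlier step, which changed only a group on the aromatic ring, this one replaces the whole six-membered aromatic ring with a chain without a ring, and the number still stays within the scatter, so at this position neither the ring nor the swap to pentyl registers on this read-out. No supporting data bear on this result.

Going by these compounds, whether a longer chain, an amine or a carboxylic acid at this same place would move the number beyond the scatter remains open. With compounds 1, 2, 3 and 4 all lying within the scatter of their neighbours, no change shown so far separates any of them.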